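Swapping furan-2-yl for phenyl: an expected cytotoxicity value

The source may hold more compounds than are shown below. What is called first, only, known or untested is meant among the compounds shown, and "the series" means these compounds.

compound 1 `CNC(=O)c1cc(Oc2ccc(C(=O)/C=C/c3ccco3)cc2)ccn1`: "not determined" (no result reported)
compound 2 `CNC(=O)c1cc(Oc2ccc(C(=O)/C=C/c3ccc(Cl)c(Cl)c3)cc2)ccn1`: 33700 nM
compound 3 `CNC(=O)c1cc(Oc2ccc(C(=O)/C=C/c3ccc(Br)cc3)cc2)ccn1`: > 50000 nM

In a functional assay on A549 cells (Homo sapiens) for cytotoxicity, read by MTT assay, with a stated time of 72 h (on this read-out lower numbers stand for stronger inhibition and higher numbers for weaker inhibition), compound 2 gives 33700 nM. Compound 3 reaches only > 50000 nM, which is a limit of this assay and not a number. Compound 1 has no number at all in this assay, so its standing cannot be placed. Compound 4 `CNC(=O)c1cc(Oc2ccc(C(=O)/C=C/c3ccccc3)cc2)ccn1` is unmeasured; it differs from compound 1 by phenyl in place of furan-2-yl on a double-bonded chain carbon bound to a double-bonded chain carbon. Within the data shown here, the only measured step, an at least 1.4-fold higher number from compound 2 to compound 3 (0.17 log units; that floor lies within the scatter), also exchanges one aryl group on the same chain carbon and lies within the scatter, and (the limit of > 50000 nM in this assay, at which 1 of the 3 values shown sits). With no number for compound 1, no size or direction of step can be expected; the step carries only a rough level. Compound 4 is expected to give about 38000 nM in this assay, between 15000 nM and 100000 nM.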

Compound 4, half-maximal inhibitory concentration: 5040 nM
For compound 4 the middle estimate is 7.5-fold (0.88 log units) above the measured one; measured number outside the range, below it.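

In this assay the plain phenyl of compound 4 gives the first clear separation at this chain carbon: hydrogen in place of bromo gives an at least 9.9-fold lower number from compound 3 to compound 4 (0.99 log units; beyond the scatter), and phenyl in place of 3,4-dichlorophenyl gives a 6.7-fold lower number from compound 2 to compound 4 (0.83 log units; beyond the scatter). The first of these steps is only a floor, since compound 3 stands at a limit of the assay: the limit of > 50000 nM in this assay, at which 1 of the 4 values shown sits. Among these three compounds, both halogen-bearing aryl groups thus give higher numbers than phenyl. Going by these compounds, how furan-2-yl compares with phenyl stays open. So does the effect of a methoxy group or an amine on the phenyl ring.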